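From 4-bromophenyl to 3-iodophenyl on the shared core

This account rests on a few compounds, and the source may have more. Where it says the series, first, only, none or still open, it means among the compounds named here.

Compound 1 `COc1cccc(-c2nc(N)c(Oc3ccccc3OC)c(OCCO)n2)c1`: 30500 nM
Compound 2 `COc1ccccc1Oc1c(N)nc(-c2ccc(Br)cc2)nc1OCCO`: 11800 nM

In a functional assay on B16 cells (Mus musculus) for cytotoxicity, read by CCK-8 assay, with a stated time of 24 h (a lower number here means a stronger inhibitor, a higher number a weaker inhibitor), compound 2 holds the lower of the two numbers at 11800 nM and so stands lowest so far. Compound 3 `COc1ccccc1Oc1c(N)nc(-c2cccc(I)c2)nc1OCCO` is not yet measured and carries 3-iodophenyl in place of 4-bromophenyl on an aromatic carbon at the same place. Among the measured compounds shown here, with only one modest measured step (a 2.6-fold lower number from compound 1 to compound 2 (0.41 log units; beyond the scatter)) to go on, a change of similar or smaller size is expected in this assay and it leans towards a higher number. The expected step (a 1.3-fold higher number from compound 2 to compound 3 (0.10 log units; within the scatter)) may stay within the scatter. Compound 3 is estimated at 15000 nM with an expected range from 6000 nM to 35000 nM for this measurement.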

Compound 3, half-maximal inhibitory concentration: 20300 nM
Compound 3: the middle estimate sits 1.4-fold (0.13 log units) below what was measured; measured number inside the range.
By their numbers in this assay, from the lowest: compounds 2, 3 and 1 (each within the scatter of the next, the first and the last beyond it).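

In this assay, 3-iodophenyl in place of 4-bromophenyl at this position gives a step within the scatter (a 1.7-fold higher number from compound 2 to compound 3 (0.24 log units; within the scatter)), so the change does not separate these two groups. Iodo in place of methoxy also stays within the scatter (a 1.5-fold lower number from compound 1 to compound 3 (0.18 log units; within the scatter)), which leaves compound 3 unresolved from both neighbours, although compound 1 and compound 2 themselves lie beyond the scatter of each other. No evidence on the cause of these numbers is available.

Still open, as far as these compounds go, is how 3-bromophenyl or 4-iodophenyl would read here, which would separate the halogen from its place on the ring. Also open, from the compounds shown here alone, is whether an aminophenyl or a carboxyphenyl group would move the number further.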